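The source may hold more compounds than are shown below. What is called first, only, known or untested is meant among the compounds shown, and "the series" means these compounds.

Measured compounds in a functional assay on HCT-116 cells (Homo sapiens) for inhibition, read by MTT assay, with a stated time of 48 h; on this read-out higher numbers stand for weaker inhibition and lower numbers for stronger inhibition:

compound 1 `COc1ccc(-n2c(SC)nnc2-c2cc(OC)c(OC)c(OC)c2)cc1` — > 60000 nM
compound 2 `CCSc1nnc(-c2cc(OC)c(OC)c(OC)c2)n1-c1ccc(OC)cc1` — > 60000 nM
compound 3 `COc1cc(-c2nnc(SC)n2-c2ccc(N(C)C)cc2)cc(OC)c1OC` — > 60000 nM

Each of these three values is a limit of this assay, not a number. The value of compound 1 is such a limit. The value of compound 2 is such a limit. The value of compound 3 is such a limit. All three values sit at the limit of > 60000 nM in this assay, at which 3 of the 3 values shown sit, so no ordering among the three compounds can be read.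

From compound 1 to compound 2 the change is methyl in place of hydrogen on a saturated chain carbon bound to a sulfur; the step is a step that the two limits leave unreadable from compound 1 to compound 2. From compound 1 to compound 3 the change is dimethylamino in place of methoxy on an aromatic carbon; the step is a step that the two limits leave unreadable from compound 1 to compound 3.

Compound 4 `CCSc1nnc(-c2cc(OC)c(OC)c(OC)c2)n1-c1ccc(N(C)C)cc1` is not yet measured in this assay. It differs from compound 3 by methyl in place of hydrogen on a saturated chain carbon bound to a sulfur, the same change as from compound 1 to compound 2, at a place described in the same words. The two cores differ by dimethylamino in place of methoxy on an aromatic carbon.

For compound 4 the expected step is a number no higher from compound 3 to compound 4 (the limit leaves the size open), resting on the unreadable a step that the two limits leave unreadable from compound 1 to compound 2 and on (the limit of > 60000 nM in this assay, at which 3 of the 3 values shown sit). The expected value of compound 4 is 60000 nM, between 20000 nM and 200000 nM, with a limit the most likely outcome.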

Compound 4, half-maximal inhibitory concentration: > 60000 nM
Compound 4 was reported as a limit; the forecaster's own chance of this, stated with the estimate: 85%; the middle value lies on the limit itself.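

In this assay compound 4 gives > 60000 nM, which is a limit of the assay and not a number. No step from compound 3 or compound 2 to compound 4 can be read, because all four compounds stand at one limit: the limit of > 60000 nM in this assay, at which 4 of the 4 values shown sit.

The compounds shown leave open whether methylsulfanyl to ethylsulfanyl, or dimethylamino in place of methoxy, changes inhibition at all.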